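A few compounds are considered here, and "the series" means these few. Any claim that something is new, unique, unknown or untested is made for them only; others in the source may bear on it.

Measured compounds:
compound 1, `O=C(/C=C\Nc1ccc(O)cc1)c1cn(-c2ccccc2)nc1-c1ccc(Cl)cc1`, 1500 nM
compound 2, `COc1ccc(N/C=C\C(=O)c2cn(-c3ccccc3)nc2-c2ccc(Cl)cc2)cc1`, 6890 nM

In a functional assay on U-87MG ATCC cells (Homo sapiens) for antiproliferative activity, read by MTT assay, with a stated time of 48 h (a lower number here means a stronger inhibitor, a higher number a weaker inhibitor), compound 1 gives 1500 nM, and compound 2 gives 6890 nM. Compound 2 therefore stands at the highest of the two numbers, the weaker of the pair: the step of a 4.6-fold higher number from compound 1 to compound 2 (0.66 log units; beyond the scatter) separates it from compound 1.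

Compound 3, `COc1ccc(N/C=C\C(=O)c2cn(-c3ccccc3)nc2-c2ccc(OC)cc2)cc1`, has not yet been measured in this assay. It differs from compound 2 by methoxy in place of chloro on an aromatic carbon. Among the measured compounds shown here, no measured step touches this position: the only step seen, from compound 1 to compound 2, concerns the oxygen on the other aromatic ring, and a methoxy group already sits on that side of compound 3 just as it does in compound 2. For the measured compounds named here, the one step on hand, a 4.6-fold higher number from compound 1 to compound 2 (0.66 log units; beyond the scatter), shows that a single small change can move the number beyond the scatter, but it gives no direction for the present change. The expected step is therefore small, a 1.2-fold higher number from compound 2 to compound 3 (0.06 log units; within the scatter), and compound 3 is estimated at 8000 nM, within 2500 nM to 25000 nM.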

Compound 3, half-maximal inhibitory concentration: > 50000 nM
Compound 3: no number, only a limit; the forecaster's own chance of this, stated with the estimate: 10%; at least 6.2-fold (0.79 log units) between middle value and limit.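

In this assay compound 3 gives no number but a limit: the limit of > 50000 nM in this assay, at which 1 of the 3 values shown sits.

Even read from that limit, the change from 4-chlorophenyl to 4-methoxyphenyl, on an aromatic carbon para to a large group, gives an at least 7.2-fold higher number from compound 2 to compound 3 (0.86 log units; beyond the scatter), so this position, which the earlier step on the other aromatic ring did not touch, does not accept every small group alike. The exchange is slight in what is counted, with methoxy bringing 2 heavy atoms and 1 hydrogen-bond acceptor where chloro has 1 heavy atom and none, yet in this pair chloro is the group that keeps a measurable value, with compound 2 at 6890 nM.

The compounds shown leave open how far past the limit compound 3 really lies, and which feature of methoxy matters here, since a single pair cannot separate the added oxygen from the added carbon. They also leave open whether a methyl, a fluoro, a hydroxy or an amine at this place would stay near compound 2, and whether the hydroxy group of compound 1 would change the outcome when paired with 4-methoxyphenyl.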